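The compounds below may be only part of what the source reports. "The series", "measured", "known", "first", "only" and "open" are said of these compounds alone.

Series notes. Three compounds have numbers in a physicochemical assay for acid dissociation. Compound 1 `c1ccc(Oc2ccc3c(NCCCNCc4ccco4)ccnc3c2)cc1` gives 9.28. Compound 2 `COc1cccc(CNCCCNc2ccnc3cc(-c4ccc(C(F)(F)F)cc4)ccc23)c1O` gives 9.47, and compound 3 `COc1ccc(F)cc1CNCCCNc1ccnc2cc(Cc3ccc(F)cc3)ccc12` gives 9.47. The three values sit close together: the gaps from compound 1 to compound 2 and to compound 3 are both within the scatter, so no ranking among them can be drawn.

Compound 4 `COc1ccc(Oc2ccc3c(NCCCNCc4ccco4)ccnc3c2)cc1` is unmeasured. It differs from compound 1 by methoxy in place of hydrogen on an aromatic carbon, on an aromatic carbon of a six-membered aromatic ring of carbon only, para to a large group; phenoxy becomes 4-methoxyphenoxy. Going by the values given here, the change sits on the outer ring, remote from the chain, and no measured pair here shows what such a change does. A step of a number 0.02 log units higher from compound 1 to compound 4 (within the scatter) is expected, that is, nothing beyond the scatter. Compound 4 is estimated at 9.3, with a range of 9 to 9.6.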

Compound 4, acid dissociation constant: 9.28
Compound 4: the middle estimate sits 0.02 log units above what was measured; measured number inside the range.
By their numbers in this assay, from the lowest: compounds 1, 4, 2 and 3 (each within the scatter of the next).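

In this assay, going by these compounds alone, the only pair differing in one place shows no change at the digits printed from compound 1 to compound 4 (within the scatter) on going from phenoxy to 4-methoxyphenoxy. Methoxy in place of hydrogen on an aromatic carbon, para to a large group, therefore leaves this read-out within the scatter, which the earlier compounds, differing in several places, could not show. No measured information bears on the reason for this result. Still open, on these data alone, is whether an amine or a carboxylic acid at this position would behave the same way. Within the data shown here, a longer chain in place of the one in compound 1 also remains open.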